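The source may report more compounds than this note shows. Statements on the series, on what has been measured and on what is new or still open speak of the compounds shown alone.

Compound 1, `C=CCOc1ccc(C(=O)Nc2cccc(C)n2)cc1`, gives 31700 nM in an in vitro assay on HEK-tsA201 cells for antagonist activity at Neuronal acetylcholine receptor; alpha3/beta4 (Homo sapiens), read by fluorescence and calcium flux; a lower number here means a stronger inhibitor, a higher number a weaker inhibitor. Compound 2, `C=CCOc1ccc(C(=O)Nc2cccc(CC)n2)cc1`, carries one added carbon, (methyl in place of hydrogen on a saturated chain carbon bound to an aromatic carbon), and gives 27400 nM; the step of a 1.2-fold lower number from compound 1 to compound 2 (0.06 log units; within the scatter) is small. Compound 3, `CCCCCNc1cccc(NC(=O)c2ccc(OCCC)cc2)n1`, is built on a different core, and the difference between the two cores is not broken down here. For compound 3 only a limit of this assay is reported, > 100000 nM. Compound 4, `CCCCCCNc1cccc(NC(=O)c2ccc(OCCC)cc2)n1`, has not yet been measured; it differs from compound 3 by methyl in place of hydrogen on a saturated chain carbon, five bonds along the chain from a nitrogen on an aromatic ring. The place differs from the earlier change, bound to an aromatic carbon there, five bonds along the chain from a nitrogen on an aromatic ring here, so this is the same kind of change. The step that the limit leaves unreadable from compound 3 to compound 4 is expected to be small, resting on the earlier step of a 1.2-fold lower number from compound 1 to compound 2 (0.06 log units; within the scatter). Compound 4 is estimated at 150000 nM, most likely again reported only as a limit.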

Compound 4, half-maximal inhibitory concentration: > 100000 nM
Compound 4: only a limit was reported (the forecaster's own chance of this, stated with the estimate: 70%); the middle value does not contradict the limit.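

In this assay, among these compounds, compound 3 and compound 4 are both reported only as limits, so no step between them can be read: the limit of > 100000 nM in this assay, at which 2 of the 4 values shown sit. Going by these compounds, how strongly either compound inhibits, and whether the added methyl changes that, stays open.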